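The source may report more compounds than this note shows. Statements on the series, on what has been measured and on what is new or still open speak of the compounds shown alone.

Measured in a functional assay on CHO cells for antagonist activity at prostaglandin E2 receptor EP3 subtype (Homo sapiens), read by cAMP accumulation; on this read-out lower numbers stand for stronger inhibition and higher numbers for weaker inhibition:
compound 1, `CC(C)C(Nc1nnc[nH]1)c1ccc(-c2ccc3cccc(F)c3c2)[nH]c1=O` — 185 nM
compound 2, `CC(C)C(c1ncco1)c1ccc(-c2ccc3cccc(F)c3c2)[nH]c1=O` — 64 nM

Compound 2 gives the lowest of the two numbers in this assay; its nearest neighbour is compound 1, with the higher number, and the step between them is a 2.9-fold lower number from compound 1 to compound 2 (0.46 log units; beyond the scatter). That step, an exchange at the saturated chain carbon bound to an aromatic carbon and a saturated chain carbon, is the only one so far at that place.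

Compound 3, `CC(C)C(c1noc(=O)[nH]1)c1ccc(-c2ccc3cccc(F)c3c2)[nH]c1=O`, is not yet measured. It differs from compound 2 as follows: a group of 6 heavy atoms (2 carbon, 2 nitrogen, 2 oxygen; one five-membered aromatic ring with 3 hetero atoms) in place of a group of 5 heavy atoms (3 carbon, 1 nitrogen, 1 oxygen; one five-membered aromatic ring with 2 hetero atoms), on a saturated chain carbon bound to an aromatic carbon and a saturated chain carbon. A five-membered aromatic ring with 3 hetero atoms and one hydrogen-bond donor enters where a five-membered aromatic ring with 2 hetero atoms and no donor leaves. For the measured compounds named here, the single relevant step, a 2.9-fold lower number from compound 1 to compound 2 (0.46 log units; beyond the scatter), shows that exchanging the ring at this carbon can move the number beyond the scatter, but gives no direction for this particular ring. The expected step in this assay is therefore a 1.6-fold higher number from compound 2 to compound 3 (0.19 log units; within the scatter), a cautious drift back toward compound 1 with wide uncertainty. Compound 3 is estimated at 100 nM, range 30 nM to 350 nM.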

Compound 3, half-maximal inhibitory concentration: 41 nM
Compound 3: middle estimate off by 2.4-fold (0.39 log units), on the high side; measured number inside the range.
By their numbers in this assay, from the lowest: compounds 3 and 2 (each within the scatter of the next); then compound 1.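

In this assay, exchanging 1,3-oxazol-2-yl for a ring carrying a hydrogen-bond donor on this saturated chain carbon gives a 1.6-fold lower number from compound 2 to compound 3 (0.19 log units; within the scatter), so the donor-free and donor-bearing rings cannot be told apart here. The comparison with the (4H-1,2,4-triazol-3-yl)amino group gives a 4.5-fold lower number from compound 1 to compound 3 (0.65 log units; beyond the scatter), which shows that two groups of 6 heavy atoms, each with a five-membered aromatic ring with 3 hetero atoms, can differ beyond the scatter at this place. No measurement on hand bears on the reason for these differences.

The compounds shown leave open whether a methyl group on the ring nitrogen of compound 3 would keep its number. They also leave open how a carboxylic acid or an amine would compare at this carbon.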